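Swapping Chloro for Fluoro in Compound 3

A few compounds are considered here, and "the series" means these few. Any claim that something is new, unique, unknown or untested is made for them only; others in the source may bear on it.

Compound 1 `Cc1cc(=O)c2c(O)c(CN3CCCC3)c(O)c([C@H]3CCN(C)C[C@H]3O)c2o1`: 10%
Compound 2 `Cc1cc(=O)c2c(O)c(CN3CCC(Cc4ccccc4)CC3)c(O)c([C@H]3CCN(C)C[C@H]3O)c2o1`: 16%
Compound 3 `Cc1oc2c([C@H]3CCN(C)C[C@H]3O)c(O)cc(O)c2c(=O)c1C(O)c1ccc(Cl)cc1`: 41%

These three compounds have been measured in a functional assay on PC-3 cells (Homo sapiens) for inhibition, read by MTT assay, with a stated time of 48 h, tested at 10 uM; a higher number here means more inhibition of growth at the concentration tested, a lower number less inhibition of growth. Compound 3 stands highest of the three, and its lead over compound 2 and over compound 1 lies beyond the usual scatter of this assay. Compound 4 `Cc1oc2c([C@H]3CCN(C)C[C@H]3O)c(O)cc(O)c2c(=O)c1C(O)c1ccc(F)cc1` has not yet been measured in this assay. It differs from compound 3 in one place: fluoro in place of chloro on an aromatic carbon. Among the measured compounds shown here, no pair of measured compounds shows this exact change, so its size cannot be read from the numbers at hand. A swap of one halogen for another on an aromatic carbon is a small change, and the step of a number 5 percentage points lower from compound 3 to compound 4 (within the scatter) is expected to stay within the scatter, if anything slightly downward. Compound 4 is therefore estimated at 36%, with a range from 22% to 50%.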

Compound 4, percent growth inhibition at one concentration: 0%
Compound 4: the middle estimate sits 36 percentage points above what was measured; the measured number lies below the stated range.
By their numbers in this assay, from the lowest: compounds 4, 1 and 2 (each within the scatter of the next, the first and the last beyond it); then compound 3.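

In this assay, a swap of a single halogen atom proves decisive at this place on the ring, para to a large group: fluoro in place of chloro brings a number 41 percentage points lower from compound 3 to compound 4 (beyond the scatter), a large loss from one atom. Compounds 1 and 2 carry no 4-chlorophenyl group, so they could not show how much growth inhibition rests on this one atom. No measurement at hand explains the gap between the two halogens. From the compounds shown here alone, whether bromo, methyl or a nitrile at the same place would hold the inhibition seen with compound 3 remains open. So does the effect of a bare phenyl ring, with no halogen at all.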